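A few compounds are considered here, and "the series" means these few. Any claim that something is new, unique, unknown or untested is made for them only; others in the source may bear on it.

Measured compounds:
- compound 1 `CCC(C)(C)Cc1c[nH]c(CCc2ccc(-c3ccncc3)cc2)n1`: in a functional assay on HEK293 cells for agonist activity at Bombesin receptor subtype-3 (Homo sapiens), read by luminescence and calcium flux, with a stated time of 10 min (on this read-out lower numbers stand for an effect already at smaller amounts and higher numbers for an effect only at larger amounts of compound), compound 1 gives 305 nM
- compound 2 `CCC(C)(C)Cc1c[nH]c(CCc2ccc(-c3cccnc3)cc2)n1`: in this assay compound 2 gives 131 nM
- compound 3 `CCC(C)(C)Cc1c[nH]c(CCc2ccc(N3CCCCC3)cc2)n1`: in this assay compound 3 gives 171 nM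

Compound 1 carries the highest number of the three in this assay. Its nearest neighbour is compound 3, and that gap, a 1.8-fold lower number from compound 1 to compound 3 (0.25 log units; within the scatter), sits within the scatter. Among the compounds with values here, the gap to compound 2, a 2.3-fold lower number from compound 1 to compound 2 (0.37 log units; beyond the scatter), is beyond the scatter, so compound 2 is the only measured compound that separates from compound 1.

The next compound, compound 4 `CCC(C)(C)Cc1c[nH]c(CCc2ccc(-c3cccc(C)n3)cc2)n1`, is not yet measured. It differs from compound 1 in one place: 6-methylpyridin-2-yl in place of pyridin-4-yl on an aromatic carbon.

Within the data shown here, two measured steps bear on this change, both leaving pyridin-4-yl from the same position of the shared core. The move to pyridin-3-yl gave a 2.3-fold lower number from compound 1 to compound 2 (0.37 log units; beyond the scatter); the move to piperidin-1-yl gave a 1.8-fold lower number from compound 1 to compound 3 (0.25 log units; within the scatter). Both point the same way, toward lower numbers, but only one of them exceeds the scatter, and neither replacement is the 6-methylpyridin-2-yl group. A small step toward a lower number, at the edge of the scatter, is therefore the expectation for compound 4, with a wide range.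

Compound 4 is estimated at 200 nM in this assay, with a range from 80 nM to 600 nM. This estimate corresponds to the step of a 1.5-fold lower number from compound 1 to compound 4 (0.18 log units; within the scatter).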

Compound 4, half-maximal effective concentration: 105 nM
Estimate against measurement, compound 4: 1.9-fold (0.28 log units) above; the range from low to high includes it.
By their numbers in this assay, from the lowest: compounds 4, 2, 3 and 1 (each within the scatter of the next, the first and the last beyond it).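

In this assay, 6-methylpyridin-2-yl on the aromatic carbon para to a large group is the second replacement of pyridin-4-yl that separates from compound 1, with a 2.9-fold lower number from compound 1 to compound 4 (0.46 log units; beyond the scatter) against the scatter, so this place tolerates a substituted pyridine ring without any loss on this read-out. The new group does not separate from the other two replacements, as a 1.2-fold lower number from compound 2 to compound 4 (0.10 log units; within the scatter) and a 1.6-fold lower number from compound 3 to compound 4 (0.21 log units; within the scatter) both show, so pyridin-3-yl, piperidin-1-yl and 6-methylpyridin-2-yl form one group on these numbers, although compound 3 itself stays within the scatter of compound 1 and so goes against any clean split between pyridin-4-yl and the rest. Nothing at hand explains these steps, and the methyl group and the change of pyridine attachment arrive together in compound 4, so the step cannot be divided between them.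

Open, going by these compounds, is what pyridin-2-yl without the methyl group would give here, since that group would separate the two parts of the change. Also open, on these data alone, is how a plain phenyl ring, a morpholin-4-yl group or a carboxylic acid would read at this place.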